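Series notes: amine variation and maximal response

The source may report more compounds than this note shows. Statements on the series, on what has been measured and on what is new or still open speak of the compounds shown alone.

Measured so far:
compound 1 `NCCC(=O)Nc1cccc2c1cnn2S(=O)(=O)c1cccc2ccccc12`: 100%
compound 2 `CN(C)CCC(=O)Nc1ccc2cnn(S(=O)(=O)c3cccc4ccccc34)c2c1`: 100%

In a functional assay on HeLa cells for antagonist activity at 5-hydroxytryptamine receptor 6 (Homo sapiens), read by cAMP accumulation (a higher number here means a larger maximal response, a lower number a smaller maximal response), compound 1 gives 100% and compound 2 gives 100%, so compound 2 stands level with compound 1 at the digits shown, within the scatter. Compound 3 `CCN(CC)CCC(=O)Nc1ccc2cnn(S(=O)(=O)c3cccc4ccccc34)c2c1` awaits measurement in this assay. Against compound 2 it carries the change (diethylamino in place of dimethylamino on a saturated chain carbon, two bonds along the chain from a carbonyl carbon), dimethylamino leaving and diethylamino entering. Within the data shown here, no measured pair spans this change, and both measured compounds sit at the same level, so no step beyond the scatter is expected; the expected step is no change at the digits printed from compound 2 to compound 3 (within the scatter). Compound 3 is estimated at 100%, within the range 85% to 105%.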

Compound 3, largest response reached (reported as Imax), in percent of the reference or control that the assay uses: 100%
Estimate against measurement, compound 3: no gap at the digits printed; measured number inside the range.
By their numbers in this assay, from the lowest: compounds 1, 2 and 3 (each within the scatter of the next).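

The maximal response in this assay runs no change at the digits printed from compound 2 to compound 3 (within the scatter) when diethylamino, with 5 heavy atoms, replaces dimethylamino, with 3. Among these compounds, this gives the first matched step at this position, on a saturated chain carbon, two bonds along the chain from a carbonyl carbon, and the change leaves the read-out level. Nothing available bears on why the response stays level. Still open, going by these compounds, is whether that level holds with a ring amine such as piperidine or morpholine in this place, or with a longer chain between amine and carbonyl.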